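Methoxy in place of cyano: compound 1 to compound 4

The source may report more compounds than this note shows. Statements on the series, on what has been measured and on what is new or still open speak of the compounds shown alone.

compound 1 `COc1ccc(S(=O)(=O)N2CCc3cccc(-c4ccc(C#N)cc4)c32)cc1` — 17.2 nM
compound 2 `COc1ccc(S(=O)(=O)N2CCc3cccc(-c4c(F)c(F)c(F)c(F)c4F)c32)cc1` — 1780 nM
compound 3 `COc1ccc(S(=O)(=O)n2ccc3cccc(-c4ccc(F)cc4)c32)cc1` — 170 nM

In a functional assay on MKN-45 cells (Homo sapiens) for inhibition, with a stated time of 72 h (a higher number here means a weaker inhibitor, a lower number a stronger inhibitor), compound 1 gives 17.2 nM, the lowest of the three numbers shown. Compound 3 gives 170 nM, and compound 2 gives 1780 nM; both of these lie beyond the scatter from compound 1, with compound 2 the furthest away. Within the data shown here, the series has no pair of measured compounds that differs in one place, so no step size can be read directly from it.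

Compound 4 `COc1ccc(-c2cccc3c2N(S(=O)(=O)c2ccc(OC)cc2)CC3)cc1` differs from compound 1 as follows: methoxy in place of cyano on an aromatic carbon.

Nothing measured here isolates this change. A modest weakening relative to compound 1 is expected, a step of a 2.6-fold higher number from compound 1 to compound 4 (0.42 log units; beyond the scatter), near the edge of the scatter rather than far beyond it. Compound 4 is therefore estimated at 45 nM, with a range from 12 nM to 180 nM.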

Compound 4, half-maximal inhibitory concentration: 211 nM
Beside the measured number, compound 4's estimate is 4.7-fold (0.67 log units) below it; measured number outside the range, above it.
By their numbers in this assay, from the lowest: compound 1; then compounds 3 and 4 (each within the scatter of the next); then compound 2.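

Methoxy in place of cyano is the only single-place change in the series so far, and in this assay it gives a 12-fold higher number from compound 1 to compound 4 (1.09 log units; beyond the scatter) and marks a large step. This position is therefore not indifferent to the group it carries, even though both groups count the same heavy atoms and one hydrogen-bond acceptor. Nothing available explains the size of this step.

Still open, from the compounds shown here alone, is where a carboxylic acid, an amine or a plain hydrogen at this place would fall relative to compound 1. Also open, going by these compounds, is whether this change gives a step of similar size on the core of compound 3.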